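The source may hold more compounds than are shown below. What is called first, only, known or untested is meant among the compounds shown, and "the series" means these compounds.

Compound 1 `CN1CCN(c2nc(N)nc(COc3ccccc3)n2)CC1` gives 507 nM in an assay on HEK293 cells for displacement of a labelled ligand from 5-hydroxytryptamine receptor 6 (Homo sapiens), read by radioligand binding, with a stated time of 1 h (a lower number here means a stronger inhibitor, a higher number a weaker inhibitor), the higher of the two numbers recorded so far. Among the compounds with values here, its only neighbour is compound 2 `CN1CCN(c2nc(N)nc(COc3cccc(Cl)c3)n2)CC1`, which in this assay gives 148 nM; the two are linked by a 3.4-fold lower number from compound 1 to compound 2 (0.53 log units; beyond the scatter), brought about by chloro in place of hydrogen on an aromatic carbon. Compound 3 `Cc1cc(Cl)ccc1OCc1nc(N)nc(N2CCN(C)CC2)n1` has not yet been measured. Relative to compound 1 it shows (4-chloro-2-methylphenyl in place of phenyl on an oxygen on a saturated carbon). Within the data shown here, the one measured step that bears on this change is the one from compound 1 to compound 2, since it also introduces a chlorine on the same ring, and it was modest but beyond the scatter. Among the measured compounds shown here, in compound 3 the chlorine occupies a different position on that ring and a methyl enters with it, and no measured step speaks to either of these. A lowering of the number in this assay is therefore expected, of a size comparable to the step already seen, though with wider uncertainty. Compound 3 is estimated to give about 200 nM in this assay, between 70 nM and 600 nM. This estimate amounts to a 2.5-fold lower number from compound 1 to compound 3 (0.40 log units; beyond the scatter).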

Compound 3, inhibition constant: 911 nM
Compound 3: the middle estimate sits 4.6-fold (0.66 log units) below what was measured; the whole stated range lies below it.
By their numbers in this assay, from the lowest: compound 2; then compounds 1 and 3 (each within the scatter of the next).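

In this assay, a chlorine on the ring does not on its own bring the lower number that compound 2 showed: 4-chloro-2-methylphenyl in place of phenyl on the oxygen gives a 1.8-fold higher number from compound 1 to compound 3 (0.25 log units; within the scatter), so this larger group reads the same as plain phenyl. Set against 3-chlorophenyl at the same place, the same group gives a 6.2-fold higher number from compound 2 to compound 3 (0.79 log units; beyond the scatter), so the step from compound 1 to compound 2 does not carry over to every chlorine-bearing ring, and what happens at this position depends on more than the presence of chlorine. Nothing at hand explains this result.

On these data alone, what stays open is how 4-chlorophenyl or 2-methylphenyl alone would read in this assay, so the place of the chlorine and the added methyl cannot yet be told apart as the source of the distance from compound 2. Equally open, as far as these compounds go, is what a methoxy group or a nitrile on the ring, or a longer chain carrying the oxygen, would do to the number on the core of compound 1.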